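This account rests on a few compounds, and the source may have more. Where it says the series, first, only, none or still open, it means among the compounds named here.

Measured compounds:
compound 1, `Cc1cc(Nc2cc(-c3ccccc3)[nH]n2)n2nc(SCc3ccccc3Br)nc2n1`, 3650 nM
compound 2, `Cc1cc(Nc2ccn(Cc3ccc(F)cc3)n2)n2nc(SCc3ccc(Br)cc3)nc2n1`, 3070 nM

Both were tested in a functional assay on MGC-803 cells (Homo sapiens) for inhibition, read by MTT assay, with a stated time of 72 h; a lower number here means a stronger inhibitor, a higher number a weaker inhibitor. Compound 1 carries the highest number of the two. Its nearest neighbour is compound 2, whose result of 3070 nM lies within the usual scatter of the result of compound 1, so the two compounds cannot be told apart on these data. Within the data shown here, no pair of measured compounds differs in a single place, so no measured step is available to lean on.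

Compound 3, `Cc1cc(Nc2cc(-c3ccccc3)[nH]n2)n2nc(SCC3CC3)nc2n1`, has not yet been measured in this assay. It differs from compound 1 in one place: cyclopropyl in place of 2-bromophenyl on a saturated chain carbon bound to a sulfur. Among the measured compounds shown here, the two measured values give no guidance on what this exchange does, since no measured compound carries a cyclopropyl at that position. In the absence of a measured step, a modest move toward a higher number, that is a weaker inhibitor, is expected, of a size that may not clear the scatter, and this expected change is the step of a 1.5-fold higher number from compound 1 to compound 3 (0.18 log units; within the scatter). Compound 3 is therefore estimated at 5500 nM, with an expected range from 2200 nM to 14000 nM.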

Compound 3, half-maximal inhibitory concentration: 16100 nM
Compound 3: the middle estimate sits 2.9-fold (0.47 log units) below what was measured; the measured number lies above the stated range.
By their numbers in this assay, from the lowest: compounds 2 and 1 (each within the scatter of the next); then compound 3.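

In this assay, the result shows that this position, on a saturated chain carbon bound to a sulfur, is sensitive to the group it carries: cyclopropyl in place of 2-bromophenyl gives a 4.4-fold higher number from compound 1 to compound 3 (0.64 log units; beyond the scatter), a step beyond the scatter and the only single-place comparison among these compounds. The exchange changes several things at once, replacing a six-membered aromatic ring of carbon only and its bromine with a smaller three-membered non-aromatic ring of carbon only, so this one step cannot show which of these differences matters. No measurement is available to explain the step.

The compounds shown leave open whether a plain benzyl, which keeps the aromatic ring but has no bromine, would stay close to compound 1 or move toward compound 3. They also do not show how this position would respond to a longer chain or a terminal amine, and compound 2 cannot settle either question, since it differs from compound 1 and compound 3 in more than one place.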